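This account rests on a few compounds, and the source may have more. Where it says the series, first, only, none or still open, it means among the compounds named here.

Compound 1, `Clc1cccc(N2CCN(c3ncnc4[nH]ncc34)CC2)c1`, gives 107 nM in an assay for inhibition of ribosomal protein S6 kinase beta-1 variant D18H,T412E (Homo sapiens), read by a luciferase reporter and chemiluminescence, with a stated time of 3 h; on this read-out higher numbers stand for weaker inhibition and lower numbers for stronger inhibition.
Compound 2, `CCc1n[nH]c2ncnc(N3CCN(c4cc(Cl)ccc4C)CC3)c12`, gives 6 nM in this assay.

Among the compounds with values here, of these two numbers, the one for compound 2 is the lower, and the gap to compound 1 is beyond the usual scatter, so compound 2 counts as the stronger inhibitor of the pair. The two compounds differ in more than one place, so no single change can be credited for that gap.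

Compound 3, `Cc1ccc(Cl)cc1N1CCN(c2ncnc3[nH]nc(Br)c23)CC1`, is the next step. It keeps the whole of compound 2 except for one exchange: bromo in place of ethyl on an aromatic carbon. Within the data shown here, no pair of measured compounds shows this exchange on its own, so there is no measured step to lean on. Bromo and ethyl are both small, uncharged groups without donors or acceptors, and the rest of compound 2 is unchanged, so the expected step of a 1.7-fold higher number from compound 2 to compound 3 (0.22 log units; within the scatter) is small, with no clear direction beyond the scatter. Compound 3 is therefore expected to give about 10 nM in this assay, within a range of 3 nM to 40 nM.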

Compound 3, half-maximal inhibitory concentration: 7 nM
Estimate against measurement, compound 3: 1.4-fold (0.15 log units) above; the range from low to high includes it.
By their numbers in this assay, from the lowest: compounds 2 and 3 (each within the scatter of the next); then compound 1.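

Bromo in place of ethyl, on this aromatic carbon of the five-membered ring, gives a 1.2-fold higher number from compound 2 to compound 3 (0.07 log units; within the scatter) in this assay and so leaves the number unchanged within the usual scatter. Within the data shown here, this is the first direct reading at this position: a group of one heavy atom and a group of two heavy atoms, neither with hydrogen-bond donors or acceptors, cannot be told apart here, which means the exchange can be made without a measurable loss in this assay. Nothing measured on these compounds offers an explanation for this match.

On these data alone, it remains open how much either group contributes compared with plain hydrogen on this carbon, since compound 1 differs from both compounds in more than one place. How an amine, a carboxylic acid or a longer chain such as butyl would behave at this position is also unknown.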